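The source may report more compounds than this note shows. Statements on the series, on what has been measured and on what is new or still open speak of the compounds shown alone.

Going by the values given here, in a functional assay on A549 cells (Homo sapiens) for antiproliferative activity, read by MTT assay, with a stated time of 48 h (a higher number here means a weaker inhibitor, a lower number a stronger inhibitor), compound 3 `O=C(/C=C\Nc1ccc(Cl)cc1)c1cn(-c2ccccc2)nc1-c1ccc(F)cc1` gives 6700 nM, the second highest of the three numbers measured so far. Compound 1 `O=C(/C=C\Nc1ccc(Cl)cc1)c1cn(-c2ccccc2)nc1-c1ccccc1` gives 14100 nM in this assay, and compound 2 `COc1ccc(N/C=C\C(=O)c2cn(-c3ccccc3)nc2-c2ccccc2)cc1` gives 3250 nM. Compound 4 `COc1ccc(N/C=C\C(=O)c2cn(-c3ccccc3)nc2-c2ccc(F)cc2)cc1` differs from compound 3 by methoxy in place of chloro on an aromatic carbon. The same change, made on the core without the fluoro, gave a 4.3-fold lower number from compound 1 to compound 2 (0.64 log units; beyond the scatter), while the fluoro itself gave a 2.1-fold lower number from compound 1 to compound 3 (0.32 log units; beyond the scatter). Among the compounds with values here, the two changes have not yet been combined in any measured compound, so the expectation rests on the one step alone: a modest lowering of the number is expected, a 4.2-fold lower number from compound 3 to compound 4 (0.62 log units; beyond the scatter). Compound 4 is therefore estimated at 1600 nM in this assay, with a range from 700 nM to 3600 nM.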

Compound 4, half-maximal inhibitory concentration: 8900 nM
Beside the measured number, compound 4's estimate is 5.6-fold (0.75 log units) below it, and the stated range ends below it.
By their numbers in this assay, from the lowest: compound 2; then compounds 3, 4 and 1 (each within the scatter of the next, the first and the last beyond it).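

Going by these compounds alone, with the fluoro present, methoxy in place of chloro no longer separates the pair (a 1.3-fold higher number from compound 3 to compound 4 (0.12 log units; within the scatter)), so the lowering seen on the core without the fluoro does not carry over: the same change on two cores in this assay, a 4.3-fold lower number (0.64 log units; beyond the scatter) from compound 1 to compound 2 and a 1.3-fold higher number (0.12 log units; within the scatter) from compound 3 to compound 4, 5.8-fold (0.76 log units) apart, beyond the scatter of two such steps. With the methoxy present, fluoro in place of hydrogen raises the number (a 2.7-fold higher number from compound 2 to compound 4 (0.44 log units; beyond the scatter)), opposite in direction to its step on the chloro compounds: the same change on two cores in this assay, a 2.1-fold lower number (0.32 log units; beyond the scatter) from compound 1 to compound 3 and a 2.7-fold higher number (0.44 log units; beyond the scatter) from compound 2 to compound 4, 5.8-fold (0.76 log units) apart, beyond the scatter of two such steps. Across these four compounds, the two changes do not add. On these data alone, whether this dependence extends to other groups in place of chloro, such as an amine or a nitrile, remains open.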